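The source may report more compounds than this note shows. Statements on the series, on what has been measured and on what is new or still open speak of the compounds shown alone.

In a functional assay for inhibition, with Rattus norvegicus as the target (on this read-out higher numbers stand for weaker inhibition and lower numbers for stronger inhibition), the measured compounds are:
compound 1 `CCCCc1cc(OC)c2ccccc2c1OC(C)=O` with 440 nM
compound 2 `CCCCc1cc(OC)c2ccccc2c1O` with 1470 nM
compound 3 `CCCCc1cc(OC)c2ccccc2c1OC` with 40900 nM

Compound 1 has the lowest number of the three, so it is the strongest inhibitor among them. Compound 4 `CCCCc1cc(OC)c2c(C)cccc2c1OC(C)=O` keeps its acetyl and carries methyl in place of hydrogen on an aromatic carbon. Among the measured compounds shown here, all the measured steps change the group on the oxygen: a 3.3-fold higher number from compound 1 to compound 2 (0.52 log units; beyond the scatter) is modest, while a 93-fold higher number from compound 1 to compound 3 (1.97 log units; beyond the scatter) and a 28-fold higher number from compound 2 to compound 3 (1.44 log units; beyond the scatter) are large. For the measured compounds named here, none touches an aromatic carbon, so they show only that small changes can matter here and set no direction. A small step towards a higher number is tentatively expected. The expected step is a 1.6-fold higher number from compound 1 to compound 4 (0.20 log units; within the scatter) and its uncertainty is wide. Compound 4 is estimated at 700 nM (range 150 nM to 3000 nM).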

Compound 4, half-maximal inhibitory concentration: 620 nM
For compound 4 the middle estimate is 1.1-fold (0.05 log units) above the measured one, within the range that was stated.
By their numbers in this assay, from the lowest: compounds 1 and 4 (each within the scatter of the next); then compound 2; then compound 3.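

In this assay putting methyl in place of hydrogen on an aromatic carbon gives a 1.4-fold higher number from compound 1 to compound 4 (0.15 log units; within the scatter) and so no difference that can be told from the scatter. Among the compounds shown here, this carbon of the shared core therefore accepts a methyl, whereas changing the group on the oxygen gave steps as large as a 93-fold higher number from compound 1 to compound 3 (1.97 log units; beyond the scatter) in the earlier compounds. Nothing available explains this result.

As far as these compounds go, whether an amine, a carboxylic acid or a longer chain would be accepted on this carbon remains open. Also open, from the compounds shown here alone, is whether the methyl would have the same small effect with hydrogen instead of acetyl on the oxygen.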